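The source may hold more compounds than are shown below. What is called first, only, known or untested is meant among the compounds shown, and "the series" means these compounds.

In a functional assay on brain (Rattus norvegicus, strain Wistar) for inhibition (on this read-out higher numbers stand for weaker inhibition and lower numbers for stronger inhibition), compound 1 `Cc1[nH]c(=O)n(C2CCCCC2)c1-c1ccc(OC(C)C)cc1` gives 13000 nM, compound 2 `CCCCCCOc1ccc(-c2c(C)[nH]c(=O)n2C2CCCCC2)cc1` gives 8500 nM and compound 3 `Cc1[nH]c(=O)n(C2CCCCC2)c1-c1ccc(C2CCCCC2)cc1` gives 28900 nM, the highest of the three numbers and so the weakest inhibition. Compound 4 `CCCCCCCCc1ccc(-c2c(C)[nH]c(=O)n2C2CCCCC2)cc1` has octyl in place of cyclohexyl on an aromatic carbon. Both measured changes that put cyclohexyl on this carbon raised the number, with a 2.2-fold higher number from compound 1 to compound 3 (0.35 log units; beyond the scatter) and a 3.4-fold higher number from compound 2 to compound 3 (0.53 log units; beyond the scatter), and both were modest. Swapping isopropyl for hexyl gave a 1.5-fold lower number from compound 1 to compound 2 (0.18 log units; within the scatter), which is within the scatter. Within the data shown here, no measured compound carries octyl, so this comparison is indirect, but a modest step to a lower number is expected in this assay. The expected step is a 2.9-fold lower number from compound 3 to compound 4 (0.46 log units; beyond the scatter). For compound 4 the estimated value is 10000 nM, with an expected range of 3500 nM to 28000 nM.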

Compound 4, half-maximal inhibitory concentration: 10300 nM
Beside the measured number, compound 4's estimate is 1.0-fold (0.01 log units) below it; measured number inside the range.
By their numbers in this assay, from the lowest: compounds 2, 4 and 1 (each within the scatter of the next); then compound 3.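

In this assay the open octyl chain gives stronger inhibition than the cyclohexyl ring on this aromatic carbon, with a 2.8-fold lower number from compound 3 to compound 4 (0.45 log units; beyond the scatter) here, so a ring is not needed at this place. Octyl cannot be told apart from hexyloxy, with a 1.2-fold higher number from compound 2 to compound 4 (0.08 log units; within the scatter) within the scatter, or from isopropoxy, with a 1.3-fold lower number from compound 1 to compound 4 (0.10 log units; within the scatter) also within the scatter, so an oxygen on the aromatic ring is not needed either. What lies behind these results remains unexplained, as no supporting evidence is available. On these data alone, whether a longer chain than octyl, an amine or a carboxylic acid on this carbon would change the number remains open.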